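This account rests on a few compounds, and the source may have more. Where it says the series, first, only, none or still open, it means among the compounds named here.

Measured so far:
compound 1 `CN(C)CCn1cnnc1-c1cc(Oc2ccc(NC(=O)N/N=C/c3ccc(Cl)cc3Cl)cc2F)ccn1` — 750 nM
compound 2 `CN(C)CCn1cnnc1-c1cc(Oc2ccc(NC(=O)N/N=C/c3c(Cl)cccc3Cl)cc2F)ccn1` — 160 nM

Working notes. In a functional assay on MKN-45 cells (Homo sapiens) for cytotoxicity, read by MTT assay, with a stated time of 72 h (on this read-out lower numbers stand for stronger inhibition and higher numbers for weaker inhibition), compound 1 gives 750 nM, and compound 2 gives 160 nM. Among the measured compounds shown here, the single measured step is a 4.7-fold lower number from compound 1 to compound 2 (0.67 log units; beyond the scatter); it is the only one in hand, and it shows that the arrangement of the two halogens on the aryl ring attached to the carbon with a double bond to nitrogen shifts the read-out. For the measured compounds named here, compound 2 thus stands at the lowest of the two numbers in this assay, with compound 1 as its only neighbour at the higher number.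

Compound 3 `CN(C)CCn1cnnc1-c1cc(Oc2ccc(NC(=O)N/N=C/c3cc(Br)c(O)c(Br)c3)cc2F)ccn1` is not yet measured. Its change from compound 2: 3,5-dibromo-4-hydroxyphenyl in place of 2,6-dichlorophenyl on a carbon with a double bond to nitrogen. Going by the values given here, no measured step covers this replacement, so the only guide is that the ring pattern on this carbon mattered once, in the step from compound 1 to compound 2. A move away from the pattern of compound 2 is therefore expected to cost rather than gain, with a 2.5-fold higher number from compound 2 to compound 3 (0.40 log units; beyond the scatter) as the expected step. For compound 3 in this assay the estimate is 400 nM, in the range 120 nM to 1500 nM.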

Compound 3, half-maximal inhibitory concentration: 4320 nM
Compound 3: middle estimate off by 11-fold (1.03 log units), on the low side; the whole stated range lies below it.
By their numbers in this assay, from the lowest: compound 2; then compound 1; then compound 3.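

In this assay, this position on the carbon with a double bond to nitrogen now shows a much wider span than the two dichlorophenyl compounds alone suggested: a 27-fold higher number from compound 2 to compound 3 (1.43 log units; beyond the scatter) is a larger step than a 4.7-fold lower number from compound 1 to compound 2 (0.67 log units; beyond the scatter). The 3,5-dibromo-4-hydroxyphenyl group also gives a higher number than the less favourable dichlorophenyl pattern, a 5.8-fold higher number from compound 1 to compound 3 (0.76 log units; beyond the scatter), so compound 3 lies beyond both dichlorophenyl compounds rather than among them. This replacement changes the halogen and adds one hydrogen-bond donor and one hydrogen-bond acceptor in a single step, and nothing at hand explains the loss or assigns it to either part of the change.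

The compounds shown leave open whether the step follows the two bromines, the hydroxyl or their combination, since no compound here separates them: a ring carrying the bromines without the hydroxyl, or the hydroxyl without the bromines, would divide the step. Also open, as far as these compounds go, is how this position responds to an amine or a carboxylic acid in place of the hydroxyl.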